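Hydroxybutyl for Phenyl on Two Related Cores

A few compounds are considered here, and "the series" means these few. Any claim that something is new, unique, unknown or untested is made for them only; others in the source may bear on it.

In a functional assay on CCRF-CEM cells (Homo sapiens) for cytotoxicity, read by MTT assay, with a stated time of 72 h (a lower number here means a stronger inhibitor of growth, a higher number a weaker inhibitor of growth), compound 3 `CSc1nc(NCc2ccccc2)c2cccnc2n1` gives 98600 nM. Compound 1 `CSc1nc(NCCCCCO)c2cccnc2n1` gives > 100000 nM, which is a limit of the assay and not a number. Compound 2 `CSc1nc(NCc2ccccc2)c2ccccc2n1` likewise gives > 100000 nM, again a limit rather than a number. The change from compound 3 to compound 1 is 4-hydroxybutyl in place of phenyl on a saturated chain carbon bound to a nitrogen on an aromatic ring, and it made an at least 1.0-fold higher number from compound 3 to compound 1 (0.00 log units; that floor lies within the scatter). The cores of compound 2 and compound 3 differ, but that difference is not broken down here. Compound 4 `CSc1nc(NCCCCCO)c2ccccc2n1` is not yet measured; it arises from compound 2 by the same change, (4-hydroxybutyl in place of phenyl on a saturated chain carbon bound to a nitrogen on an aromatic ring), at the same place. For compound 4 the expected step in this assay is a step that the limit leaves unreadable from compound 2 to compound 4, which rests on the earlier step of an at least 1.0-fold higher number from compound 3 to compound 1 (0.00 log units; that floor lies within the scatter) and on (the limit of > 100000 nM in this assay, at which 2 of the 3 values shown sit). Compound 4 is accordingly estimated at 150000 nM.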

Compound 4, concentration for total growth inhibition: > 100000 nM
Compound 4 gave a limit, no number (the forecaster's own chance of this, stated with the estimate: 85%); the middle value is on the limit's open side.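

Compound 2 and compound 4 both stand at a limit of the assay, so no step can be read between them: the limit of > 100000 nM in this assay, at which 3 of the 4 values shown sit.

The compounds shown leave open whether 4-hydroxybutyl in place of phenyl changes growth inhibition on the core of compound 2 in this assay.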